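This account rests on a few compounds, and the source may have more. Where it says the series, first, only, none or still open, it means among the compounds named here.

Working notes on the chain end. Compound 3 `COCCOc1cc(-c2cc3c(O)nc(C)nc3cc2C(C)C)ccc1Cl` gives 216 nM in a functional assay for inhibition of transient receptor potential cation channel subfamily V member 1 (Homo sapiens), read by fluorescence and calcium flux (on this read-out higher numbers stand for weaker inhibition and lower numbers for stronger inhibition), the highest number of the three measured. Compound 1 `CCOc1cc(-c2cc3c(O)nc(C)nc3cc2C(C)C)ccc1Cl` gives 12 nM and compound 2 `CCCCOc1cc(-c2cc3c(O)nc(C)nc3cc2C(C)C)ccc1Cl` gives 82 nM; the steps of an 18-fold higher number from compound 1 to compound 3 (1.26 log units; beyond the scatter) and a 2.6-fold higher number from compound 2 to compound 3 (0.42 log units; beyond the scatter) both run towards weaker inhibition at this chain. Compound 4 `Cc1nc(O)c2cc(-c3ccc(Cl)c(OCCO)c3)c(C(C)C)cc2n1` differs by hydrogen in place of methyl on an oxygen on a saturated carbon, the same difference read one bond further out being 2-methoxyethyl to 2-hydroxyethyl. For the measured compounds named here, no measured step bears on this change directly. Both changes at the chain end so far, a 6.8-fold higher number from compound 1 to compound 2 (0.83 log units; beyond the scatter) included, gave higher numbers, so for compound 4 a step of a 1.2-fold higher number from compound 3 to compound 4 (0.06 log units; within the scatter) is expected, with wide uncertainty. Compound 4 is estimated at 250 nM, range 80 nM to 800 nM.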

Compound 4, half-maximal inhibitory concentration: 557 nM
Estimate against measurement, compound 4: 2.2-fold (0.35 log units) below; low and high end bracket the measured number.
By their numbers in this assay, from the lowest: compound 1; then compound 2; then compound 3; then compound 4.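

Hydrogen in place of methyl on the chain-end oxygen does not recover inhibition: 2-hydroxyethyl in place of 2-methoxyethyl gives a 2.6-fold higher number from compound 3 to compound 4 (0.41 log units; beyond the scatter). Hydroxy in place of ethyl on the saturated chain carbon gives a 6.8-fold higher number from compound 2 to compound 4 (0.83 log units; beyond the scatter), and hydroxy in place of hydrogen there gives a 46-fold higher number from compound 1 to compound 4 (1.67 log units; beyond the scatter), so all three substituents now shown on that carbon raise the number, with no compound against this. No evidence is available to account for this order.

Going by these compounds, whether an amine or a carboxylic acid on that carbon follows the same trend stays open. So does whether any group there can match compound 1.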